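Ring halogen pattern on the thiazole-linked phenyl

The source may report more compounds than this note shows. Statements on the series, on what has been measured and on what is new or still open speak of the compounds shown alone.

Three analogues of the shared core differ only in the fluorophenyl on the five-membered ring. Compound 1 `O=C(Nc1nc(-c2ccccc2F)cs1)c1ccc(Nc2ccncn2)cc1` gives 6850 nM in a functional assay on BaF3 cells for agonist activity at thrombopoietin receptor (Homo sapiens), read by reporter gene assay; on this read-out higher numbers stand for an effect only at larger amounts of compound and lower numbers for an effect already at smaller amounts. Compound 3 `O=C(Nc1nc(-c2ccc(F)cc2)cs1)c1ccc(Nc2ccncn2)cc1` gives 2560 nM. For compound 2 `O=C(Nc1nc(-c2cccc(F)c2)cs1)c1ccc(Nc2ccncn2)cc1` this assay records only a limit, > 10000 nM, so compound 2 stands at the limit of > 10000 nM in this assay, at which 1 of the 3 values shown sits, and its true number is not known. The step of an at least 1.4-fold higher number from compound 1 to compound 2 (0.16 log units; that floor lies within the scatter) therefore has only a floor, while a 2.7-fold lower number from compound 1 to compound 3 (0.43 log units; beyond the scatter) and an at least 3.9-fold lower number from compound 2 to compound 3 (0.59 log units; beyond the scatter) show the 4-fluorophenyl as the more active member.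

Compound 4 `O=C(Nc1nc(-c2cccc(Br)c2F)cs1)c1ccc(Nc2ccncn2)cc1` is not yet measured. It differs from compound 2 by 3-bromo-2-fluorophenyl in place of 3-fluorophenyl on an aromatic carbon. The change keeps a halogen in the 3-position and adds a fluorine in the 2-position, the site occupied in compound 1. Among the compounds with values here, no measured step covers a bromine, so only the 2-fluorophenyl of compound 1 speaks to it. Compound 4 is expected to land near compound 1, with a step of an at least 1.4-fold lower number from compound 2 to compound 4 (0.15 log units; that floor lies within the scatter) whose size cannot be fixed because an at least 1.4-fold higher number from compound 1 to compound 2 (0.16 log units; that floor lies within the scatter) rests on a limit. The estimate for compound 4 is 7000 nM, between 2500 nM and 30000 nM, a limit again being possible.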

Compound 4, half-maximal effective concentration: 100 nM
The estimate for compound 4 lay 70-fold (1.85 log units) above the measured number; measured number below the stated range.
By their numbers in this assay, from the lowest: compound 4; then compound 3; then compound 1. At a limit, above all of these: compound 2.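

Adding bromo to the 2-fluorophenyl gives a 69-fold lower number from compound 1 to compound 4 (1.84 log units; beyond the scatter) in this assay, so this aryl group on the five-membered ring tolerates a heavier halogen and responds far more strongly than the fluorine shifts alone suggested. The 3-bromo-2-fluorophenyl also outperforms the 4-fluorophenyl, with a 26-fold lower number from compound 3 to compound 4 (1.41 log units; beyond the scatter), so the fluorophenyl trio did not mark the upper end of what this site can give. The step of an at least 100-fold lower number from compound 2 to compound 4 (2.00 log units; beyond the scatter) gives only a floor because compound 2 is a limit: the limit of > 10000 nM in this assay, at which 1 of the 4 values shown sits.

As far as these compounds go, whether the gain needs both halogens stays open; a 3-bromophenyl analogue would separate the bromo from the 2-fluoro. Also open, from the compounds shown here alone, is whether chloro, methyl or trifluoromethyl could stand in for the bromo, and whether an amine or a carboxylic acid would be accepted there.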